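The source may hold more compounds than are shown below. What is called first, only, known or untested is meant among the compounds shown, and "the series" means these compounds.

Compound 1 `O=C(Nc1ccc(Oc2ccncn2)cc1)Nc1cccc(C(F)(F)F)c1` gives 160 nM in an assay on isolated protein for inhibition of serine/threonine-protein kinase TNNI3K (Homo sapiens); on this read-out higher numbers stand for weaker inhibition and lower numbers for stronger inhibition. Compound 2 `CCCNc1cc(Oc2ccc(NC(=O)Nc3cccc(C(F)(F)F)c3)cc2)ncn1` gives 32 nM in this assay, and compound 3 `CC(C)CNc1cc(Oc2ccc(NC(=O)Nc3cccc(C(F)(F)F)c3)cc2)ncn1` gives 50 nM. Among the three numbers compound 3 stands second highest; the step of a 1.6-fold higher number from compound 2 to compound 3 (0.19 log units; within the scatter) lies within the scatter, whereas a 3.2-fold lower number from compound 1 to compound 3 (0.51 log units; beyond the scatter) lies beyond it.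

Compound 4 `CC(=O)Nc1cc(Oc2ccc(NC(=O)Nc3cccc(C(F)(F)F)c3)cc2)ncn1` awaits measurement in this assay. Against compound 3 the change is acetyl in place of isobutyl on a nitrogen on an aromatic ring. Within the data shown here, the steps that bear on this position are a 5.0-fold lower number from compound 1 to compound 2 (0.70 log units; beyond the scatter) and a 3.2-fold lower number from compound 1 to compound 3 (0.51 log units; beyond the scatter), both modest and both in the same direction, showing that an alkylamino group on that aromatic carbon lowers the number relative to hydrogen; a 1.6-fold higher number from compound 2 to compound 3 (0.19 log units; within the scatter) shows that reshaping the alkyl chain changes little. Among the measured compounds shown here, no measured step covers an acetyl on that nitrogen, so there is no direct analogue for the acetamido group. The expectation for compound 4 is a step toward a higher number, a 2.0-fold higher number from compound 3 to compound 4 (0.30 log units; within the scatter), near the edge of the scatter. Compound 4 is expected to give about 100 nM in this assay, within a range from 40 nM to 300 nM.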

Compound 4, half-maximal inhibitory concentration: 20 nM
The estimate for compound 4 lay 5.0-fold (0.70 log units) above the measured number; measured number outside the range, below it.
By their numbers in this assay, from the lowest: compounds 4, 2 and 3 (each within the scatter of the next, the first and the last beyond it); then compound 1.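

In this assay, this nitrogen on an aromatic ring need not carry an alkyl group: acetyl in place of isobutyl gives a 2.5-fold lower number from compound 3 to compound 4 (0.40 log units; beyond the scatter), a change beyond the scatter in the same direction as the earlier substitutions on this carbon. Acetyl in place of propyl gives a 1.6-fold lower number from compound 2 to compound 4 (0.20 log units; within the scatter), so acetamido and propylamino cannot be separated on this read-out. Acetamido in place of hydrogen gives an 8.0-fold lower number from compound 1 to compound 4 (0.90 log units; beyond the scatter), which adds an acylated nitrogen to the two alkylamino groups that lower the number relative to hydrogen.

No available evidence bears on this result. Going by these compounds, whether the free amine, a longer acyl group such as propanoyl or benzoyl, or a methanesulfonamide on the same nitrogen would follow acetyl remains open.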